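Two Close Values and a Morpholine Swap

The compounds below may be only part of what the source reports. "The series", "measured", "known", "first", "only" and "open" are said of these compounds alone.

Compound 1 `COc1ccc(-c2nc(/N=C(\N)NC(C)C)sc2-c2ccc(OC)cc2)cc1`: 9.1 uM
Compound 2 `COc1ccc(-c2nc(/N=C(\N)N(C)C)sc2-c2ccc(OC)cc2)cc1`: 4.8 uM

In a functional assay (aorta) with Rattus norvegicus as the target (a higher number here means that more compound is needed for the effect, a lower number that less compound is needed), compound 2 gives 4.8 uM, which lies within the scatter of compound 1. Compound 3 `COc1ccc(-c2nc(/N=C(\N)N3CCOCC3)sc2-c2ccc(OC)cc2)cc1` has morpholin-4-yl in place of dimethylamino on a carbon with a double bond to nitrogen. Among the measured compounds shown here, the one measured change at this place, a 1.9-fold lower number from compound 1 to compound 2 (0.28 log units; within the scatter), was small, so no step beyond the scatter is expected in this assay. That single step is thin evidence for a group with a ring. The expected change is a 1.3-fold higher number from compound 2 to compound 3 (0.10 log units; within the scatter). Compound 3 is estimated at 6 uM, with an expected range of 2.5 uM to 15 uM.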

Compound 3, concentration for half-maximal effect: 66 uM
For compound 3 the middle estimate is 11-fold (1.04 log units) below the measured one; the whole stated range lies below it.
By their numbers in this assay, from the lowest: compounds 2 and 1 (each within the scatter of the next); then compound 3.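

In this assay, this place on a carbon with a double bond to nitrogen turns out to be sensitive to the group it carries: morpholin-4-yl in place of dimethylamino gives a 14-fold higher number from compound 2 to compound 3 (1.14 log units; beyond the scatter), and morpholin-4-yl in place of isopropylamino gives a 7.3-fold higher number from compound 1 to compound 3 (0.86 log units; beyond the scatter). So the two groups without a ring stay within the scatter of each other, while the group with a ring stands clearly apart. Nothing available explains this rise.

The compounds shown leave open whether the higher number goes with the ring itself or with its oxygen. A piperidine ring, with carbon in place of that oxygen, would help separate the two.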